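A few compounds are considered here, and "the series" means these few. Any claim that something is new, unique, unknown or untested is made for them only; others in the source may bear on it.

Three compounds from this series have been examined in a functional assay on NIH3T3 cells (Mus musculus) (a higher number here means that more compound is needed for the effect, a lower number that less compound is needed), so far, and none has given a number. Compound 1 `CSCC[C@H](NC(=O)c1ccc(NCc2cncn2Cc2cccc(C)c2)cc1-c1ccccc1)C(=O)O` reaches only the limit of the measurement, with > 10 uM. Compound 2 `COC(=O)[C@H](CCSC)NC(=O)c1ccc(NCc2cncn2Cc2cccc([N+](=O)[O-])c2)cc1-c1ccccc1` likewise gives only the limit, > 10 uM. Compound 3 `COC(=O)[C@H](CCSC)NC(=O)c1ccc(NCc2cncn2Cc2ccccc2C#N)cc1-c1ccccc1`, the starting point here, also sits at the limit, with > 10 uM in this assay. Among the measured compounds shown here, the one change among measured compounds, a step that the two limits leave unreadable from compound 2 to compound 3, cannot be sized, since both ends of it rest on the limit; the only evidence is the limit of > 10 uM in this assay, at which 3 of the 3 values shown sit.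

Compound 4 `COC(=O)[C@H](CCSC)NC(=O)c1ccc(NCc2cncn2Cc2cccc(C)c2)cc1-c1ccccc1` is reached from compound 3 by 3-methylphenyl in place of 2-cyanophenyl on a saturated chain carbon bound to an aromatic nitrogen. For the measured compounds named here, no measured step bears on this change in a readable way, so no direction beyond the scatter can be expected for compound 4 in this assay, and its step from compound 3 is estimated as a step that the limit leaves unreadable from compound 3 to compound 4. Compound 4 is therefore expected to fall near 15 uM, within a range of 5 uM to 50 uM, most likely again reported only as a limit.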

Compound 4, concentration for half-maximal effect: > 10 uM
Compound 4: a limit, no number; the forecaster's own chance of this, stated with the estimate: 75%; the middle value lies beyond the limit too.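

In this assay compound 4 gives > 10 uM as a limit and not a number. Its steps from compound 1, compound 2 and compound 3 therefore cannot be read. The compounds shown leave open whether any change among them shifts the concentration needed, the only evidence being: the limit of > 10 uM in this assay, at which 4 of the 4 values shown sit.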